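A few compounds are considered here, and "the series" means these few. Any claim that something is new, unique, unknown or untested is made for them only; others in the source may bear on it.

Measured compounds:
compound 1 `CCCn1c(=O)c2nc(-c3cnn(Cc4ccc(F)cc4F)c3)[nH]c2n(CCC)c1=O`: 700 nM
compound 2 `CCCn1c(=O)c2nc(-c3cnn(-c4ccccc4)c3C(F)(F)F)[nH]c2n(CCC)c1=O`: > 6600 nM, a limit of the assay
compound 3 `CCCn1c(=O)c2nc(-c3cnn(-c4ccc(Cl)cc4)c3C(F)(F)F)[nH]c2n(CCC)c1=O`: > 6600 nM, a limit of the assay

Among the compounds with values here, in an in vitro assay on HEK293 cells for displacement of a labelled ligand from adenosine receptor A2b (Homo sapiens) (a higher number here means a weaker inhibitor, a lower number a stronger inhibitor), compound 1 gives 700 nM, the only number. Compound 2 returns > 6600 nM, which is a limit and not a number. Compound 3 likewise returns > 6600 nM, a limit. The step that the two limits leave unreadable from compound 2 to compound 3 therefore cannot be sized, because of the limit of > 6600 nM in this assay, at which 2 of the 3 values shown sit.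

Compound 4 `CCCn1c(=O)c2nc(-c3cnn(Cc4ccccc4C)c3)[nH]c2n(CCC)c1=O` is the next compound for this assay. It differs from compound 1 by 2-methylphenyl in place of 2,4-difluorophenyl on a saturated chain carbon bound to an aromatic nitrogen. Within the data shown here, none of the measured steps bears on this change: compounds 2 and 3 carry their aryl group directly on the aromatic nitrogen together with a trifluoromethyl group, and their one step is unreadable. The expectation for compound 4 thus rests on compound 1 alone, with no step beyond the scatter assumed. Compound 4 is estimated at 900 nM, with a range from 300 nM to 3000 nM, the expected step being a 1.3-fold higher number from compound 1 to compound 4 (0.11 log units; within the scatter).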

Compound 4, inhibition constant: 33 nM
The estimate for compound 4 lay 27-fold (1.44 log units) above the measured number; measured number below the stated range.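

In this assay, 2-methylbenzyl in place of 2,4-difluorobenzyl gives a 21-fold lower number from compound 1 to compound 4 (1.33 log units; beyond the scatter), so the aryl group on a saturated chain carbon bound to an aromatic nitrogen is a place where one change moves the number beyond the scatter. Within the data shown here, this is the only readable step, as the step between compound 2 and compound 3 cannot be read. No measured result shown gives a cause for this step.

The step from compound 1 to compound 4 swaps the two fluorines and the methyl group at once, so the compounds shown do not say how much each contributes, and plain benzyl or 2-fluorobenzyl would separate them. Also open, from the compounds shown here alone, is how the number responds to other groups at this place, such as 2-methoxybenzyl, 2-phenylethyl or a benzyl group carrying an amine.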